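Shortening the Chain of Compound 3

A few compounds are considered here, and "the series" means these few. Any claim that something is new, unique, unknown or untested is made for them only; others in the source may bear on it.

In a functional assay on HeLa cells (Homo sapiens) for cytotoxicity, read by MTT assay, with a stated time of 24 h (on this read-out lower numbers stand for stronger inhibition and higher numbers for weaker inhibition), compound 3 `CCCCCCCC/C=C\CCCCCCCC(=O)Nc1nnc(S[C@@H]2O[C@H](CO)[C@H](O)[C@H](O)[C@H]2O)s1` gives 8800 nM, the lowest of the three numbers and beyond the scatter from both others. Compound 1 `CCCCCCCCCCCC(=O)Nc1nnc(S[C@@H]2O[C@H](COC(C)=O)[C@H](OC(C)=O)[C@H](OC(C)=O)[C@H]2OC(C)=O)s1` gives 51900 nM, and compound 2 `CCCCCCCCCCCCCC(=O)Nc1nnc(S[C@@H]2O[C@H](COC(C)=O)[C@H](OC(C)=O)[C@H](OC(C)=O)[C@H]2OC(C)=O)s1` gives 61300 nM. Compound 4 `CCCCCCCCCCCC(=O)Nc1nnc(S[C@@H]2O[C@H](CO)[C@H](O)[C@H](O)[C@H]2O)s1` has butyl in place of dec-1-en-1-yl on a saturated chain carbon, seven bonds along the chain from a carbonyl carbon. Going by the values given here, the only measured step, a 1.2-fold higher number from compound 1 to compound 2 (0.07 log units; within the scatter), lies within the scatter, but it is a smaller chain change, and both compounds also differ from compound 3 elsewhere. Compound 4 has the same chain as compound 1, and compound 1 gives 51900 nM, so a moderate rise seems likely. The expected step is a 2.0-fold higher number from compound 3 to compound 4 (0.31 log units; beyond the scatter). For compound 4 the estimate is 18000 nM, ranging from 6000 nM to 50000 nM.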

Compound 4, half-maximal inhibitory concentration: 8700 nM
Compound 4: the middle estimate sits 2.1-fold (0.32 log units) above what was measured; the range from low to high includes it.
By their numbers in this assay, from the lowest: compounds 4 and 3 (each within the scatter of the next); then compounds 1 and 2 (each within the scatter of the next).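

In this assay, butyl in place of dec-1-en-1-yl, on a saturated chain carbon seven bonds along the chain from a carbonyl carbon, gives a 1.0-fold lower number from compound 3 to compound 4 (0.00 log units; within the scatter). Going by these compounds alone, this is the first comparison with only the chain changed near compound 3, and at this position neither the loss of the double bond nor the shorter chain moves the number beyond the scatter. No measurement here explains this result. Still open, going by these compounds, is whether a longer saturated chain, or a chain ending in an amine or a carboxylic acid, would stay within the scatter of compound 4.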